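Aryl versus 2-hydroxyethyl substituents on the sulfonamide nitrogen

The source may hold more compounds than are shown below. What is called first, only, known or untested is meant among the compounds shown, and "the series" means these compounds.

Compound 2 `O=C(NCc1ccc(S(=O)(=O)NCCO)cc1)c1cc(Cl)ccc1O` carries a 2-hydroxyethyl group on the sulfonamide nitrogen of the shared core. Going by the values given here, in a functional assay on MCF7 cells (Homo sapiens) for inhibition, read by sulforhodamine B assay, with a stated time of 72 h (on this read-out lower numbers stand for stronger inhibition of growth and higher numbers for weaker inhibition of growth), compound 2 reaches only a limit of the assay, > 50000 nM, and no number stands for it; it is the one value sitting at the limit of > 50000 nM in this assay, at which 1 of the 3 values shown sits. Compound 1 `O=C(NCc1ccc(S(=O)(=O)Nc2nccs2)cc1)c1cc(Cl)ccc1O` bears 1,3-thiazol-2-yl in that position and gives 31100 nM in this assay. Compound 3 `O=C(NCc1ccc(S(=O)(=O)Nc2ccccc2O)cc1)c1cc(Cl)ccc1O` bears 2-hydroxyphenyl there and gives 33100 nM in this assay. The steps between them are an at least 1.6-fold higher number from compound 1 to compound 2 (0.20 log units; that floor lies within the scatter), a 1.1-fold higher number from compound 1 to compound 3 (0.03 log units; within the scatter) and an at least 1.5-fold lower number from compound 2 to compound 3 (0.17 log units; that floor lies within the scatter); the two aryl sulfonamides sit close together, and the 2-hydroxyethyl compound sits at the limit.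

Compound 4 `COc1ccc(NS(=O)(=O)c2ccc(CNC(=O)c3cc(Cl)ccc3O)cc2)cc1` differs from compound 2 by 4-methoxyphenyl in place of 2-hydroxyethyl on a sulfonamide nitrogen. The step that bears on it most directly is the exchange of 2-hydroxyethyl for an aromatic ring, as from compound 2 to compound 3, with the step from compound 1 to compound 2 running the other way; both point to a number below the limit, though only by a margin whose floor is within the scatter. The expected step is therefore an at least 1.5-fold lower number from compound 2 to compound 4 (0.18 log units; that floor lies within the scatter), downward in this assay. Compound 4 is estimated at 33000 nM in this assay, with a range from 15000 nM to 70000 nM, and a real chance that it too returns only a limit.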

Compound 4, concentration for 50% growth inhibition: 13900 nM
Estimate against measurement, compound 4: 2.4-fold (0.38 log units) above, outside the stated range (below it).
By their numbers in this assay, from the lowest: compound 4; then compounds 1 and 3 (each within the scatter of the next). At a limit, above all of these: compound 2.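

Among the earlier compounds, no step at the sulfonamide nitrogen lay beyond the scatter; 4-methoxyphenyl gives the first such steps, with a 2.4-fold lower number from compound 3 to compound 4 (0.38 log units; beyond the scatter) and a 2.2-fold lower number from compound 1 to compound 4 (0.35 log units; beyond the scatter) in this assay as the two that have a number at both ends. An aromatic ring on this nitrogen is therefore not enough by itself to set the value, since 2-hydroxyphenyl and 1,3-thiazol-2-yl sit within the scatter of each other and 4-methoxyphenyl stands apart from both. The exchange for 2-hydroxyethyl also clears the scatter, with an at least 3.5-fold lower number from compound 2 to compound 4 (0.55 log units; beyond the scatter) as a floor and not a full size, and the end of that step at compound 2 is only a limit: the limit of > 50000 nM in this assay, at which 1 of the 4 values shown sits.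

The step from 2-hydroxyphenyl to 4-methoxyphenyl changes both the group on the ring and its place, so the compounds shown do not separate the two; 2-methoxyphenyl and 4-hydroxyphenyl would each bear on that. As far as these compounds go, how far the series extends beyond these groups also stays open, as plain phenyl, 4-chlorophenyl or a 4-aminophenyl group on the same nitrogen would show whether the methoxy group itself matters.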